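A Methyl Enters Where Ethyl Raised the Number

The source may report more compounds than this note shows. Statements on the series, on what has been measured and on what is new or still open speak of the compounds shown alone.

Of the compounds shown here, three built on one shared core have been measured in a functional assay on HeLa cells (Homo sapiens) for inhibition, read by cell counting, with a stated time of 4 days; on this read-out lower numbers stand for stronger inhibition and higher numbers for weaker inhibition. Compound 1 `C=C(Br)C(=O)Nc1cccc(-c2cn3nc(-c4ccc(CC)cc4)sc3n2)c1` gives 3200 nM. Compound 2 `C=C(Br)C(=O)Nc1cccc(-c2cn3nc(-c4ccc(F)cc4)sc3n2)c1` gives 870 nM. Compound 3 `C=C(Br)C(=O)Nc1cccc(-c2cn3nc(-c4ccccc4)sc3n2)c1` gives 1400 nM, the second highest number of the three: the step of a 1.6-fold higher number from compound 2 to compound 3 (0.21 log units; within the scatter) stays within the scatter, whereas the step of a 2.3-fold lower number from compound 1 to compound 3 (0.36 log units; beyond the scatter) lies beyond it.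

Compound 4 `C=C(Br)C(=O)Nc1cccc(-c2cn3nc(-c4ccc(C)cc4)sc3n2)c1` differs from compound 3 by methyl in place of hydrogen on an aromatic carbon, on an aromatic carbon of a six-membered aromatic ring of carbon only, para to a large group.

For the measured compounds named here, two measured steps bear on this change. The step of a 2.3-fold lower number from compound 1 to compound 3 (0.36 log units; beyond the scatter) shows that ethyl on this carbon went with a modestly higher number than hydrogen, and the step of a 3.7-fold lower number from compound 1 to compound 2 (0.57 log units; beyond the scatter) points the same way against ethyl. Methyl sits between hydrogen and ethyl in this series, so the expected step for compound 4 runs opposite to the step from compound 1 to compound 3, but smaller.

Compound 4 is therefore expected to give about 2000 nM in this assay, with a range from 900 nM to 4500 nM, an expected step of a 1.4-fold higher number from compound 3 to compound 4 (0.15 log units; within the scatter) that may not clear the scatter.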

Compound 4, half-maximal inhibitory concentration: 2000 nM
The estimate for compound 4 equals the measured number at the digits printed; measured number inside the range.
By their numbers in this assay, from the lowest: compounds 2, 3, 4 and 1 (each within the scatter of the next, the first and the last beyond it).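

In this assay, methyl on this aromatic carbon cannot be told apart from hydrogen (a 1.4-fold higher number from compound 3 to compound 4 (0.15 log units; within the scatter)) or from ethyl (a 1.6-fold lower number from compound 1 to compound 4 (0.20 log units; within the scatter)). The difference between hydrogen and ethyl, which does clear the scatter, thus resolves into two steps through methyl, neither of which clears it alone, so these compounds cannot show whether the number rises gradually with chain length or only once the chain reaches ethyl. Methyl stands apart only from fluoro (a 2.3-fold higher number from compound 2 to compound 4 (0.36 log units; beyond the scatter)), making this its sole step in the series beyond the scatter, although no measured property of these groups is available to account for any of these steps.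

The compounds shown leave open how this carbon would respond to a group other than a small alkyl chain or fluoro, such as chloro, methoxy, an amine or a carboxylic acid, and whether a longer chain such as propyl would extend the difference seen with ethyl. They also leave open whether methyl would give the same result on another carbon of this ring, or on a core that differs elsewhere.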